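This account rests on a few compounds, and the source may have more. Where it says the series, first, only, none or still open, it means among the compounds named here.

Measured compounds:
compound 1 `COc1cc(-c2nn(-c3cccc(NC(=O)c4cccc(C(F)(F)F)c4)c3)cc2-c2ccncc2)ccc1Cl` — > 50000 nM
compound 2 `O=C(Nc1cccc(-n2cc(-c3ccncc3)c(-c3ccc(Cl)c(O)c3)n2)c1)Nc1ccc(Cl)c(C(F)(F)F)c1` — > 32500 nM

In a functional assay on K562 cells (Homo sapiens) for inhibition, read by sulforhodamine B assay, with a stated time of 48 h (a higher number here means that more compound is tolerated, a lower number that less compound is tolerated), compound 1 gives only a limit, > 50000 nM, and no number. Compound 2 likewise gives only a limit in this assay, > 32500 nM. Among the measured compounds shown here, both values shown thus sit at a limit, as recorded in the limit of > 50000 nM in this assay, at which 1 of the 2 values shown sits, and (the limit of > 32500 nM in this assay, at which 1 of the 2 values shown sits); nothing on the measured side places compound 1 at any point within the measurable range, and no step between measured compounds can be read.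

Compound 3 `COc1cc(-c2nn(-c3cccc(NC(=O)Nc4ccc(Cl)c(Cl)c4)c3)cc2-c2ccncc2)ccc1Cl` is to be measured in this assay. Compared with compound 1 the change is (3,4-dichlorophenyl)amino in place of 3-(trifluoromethyl)phenyl on a carbonyl carbon. Compound 2 carries a (3,4-dichlorophenyl)carbamoyl-like arrangement of a urea on the same aniline side and also sits at a limit, so the urea linkage as such gives no sign of moving the read-out off the limit.

No step beyond the scatter is expected in this assay; the estimated step of a number no higher from compound 1 to compound 3 (the limit leaves the size open) is taken as essentially none. For compound 3 the expected value is 50000 nM, with a range from 20000 nM to 120000 nM, and most probably the assay will again report only a limit.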

Compound 3, concentration lethal to 50% of the cells: > 50000 nM
Compound 3 gave a limit, no number (the forecaster's own chance of this, stated with the estimate: 80%); the middle value lies on the limit itself.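

Compound 1 and compound 3 both give only a limit in this assay, and no step between them can be read: the limit of > 50000 nM in this assay, at which 2 of the 3 values shown sit.

The compounds shown leave open whether (3,4-dichlorophenyl)amino and 3-(trifluoromethyl)phenyl on the carbonyl carbon differ at all in this assay, and where the true values of compound 1 and compound 3 lie.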